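The source may report more compounds than this note shows. Statements on the series, on what has been measured and on what is new or still open speak of the compounds shown alone.

Of the compounds shown here, two have so far been tested in an ADME assay on RAW264.7 cells (Mus musculus) for cytotoxicity, read by MTT assay, with a stated time of 48 h; on this read-out higher numbers stand for lower toxicity in this test and lower numbers for higher toxicity in this test. Compound 1 `CC(=O)OC[C@H]1O[C@H](OC[C@@H](Cn2cc(CN(c3nc(-c4ccc(F)cc4)no3)C3CCCCC3)nn2)OC(C)=O)C=C[C@@H]1OC(C)=O` gives 31.5 ug/mL. Compound 2 `COc1ccc(-c2noc(N(Cc3cn(C[C@H](CO[C@@H]4C=C[C@H](OC(C)=O)[C@@H](COC(C)=O)O4)OC(C)=O)nn3)C3CCCCC3)n2)cc1` gives 86.3 ug/mL, the highest of the two numbers, and the step of a 2.7-fold higher number from compound 1 to compound 2 (0.44 log units; beyond the scatter) lies beyond the scatter, so compound 2 stands clearly apart from compound 1. Compound 3 `CC(=O)OC[C@H]1O[C@H](OC[C@@H](Cn2cc(CN(c3nc(-c4ccc(C(F)(F)F)cc4)no3)C3CCCCC3)nn2)OC(C)=O)C=C[C@@H]1OC(C)=O` differs from compound 2 in one place: trifluoromethyl in place of methoxy on an aromatic carbon. Going by the values given here, no measured step covers this exact exchange. Among the compounds with values here, the only step that bears on it is a 2.7-fold higher number from compound 1 to compound 2 (0.44 log units; beyond the scatter), which changed the group on the same aromatic carbon, and there the fluorine-bearing group gave the lower number. Within the data shown here, with only that single step to go on, compound 3 is expected to show a 1.9-fold lower number from compound 2 to compound 3 (0.28 log units; within the scatter), a shift whose direction remains uncertain. Compound 3 is therefore estimated at 45 ug/mL, with a range from 20 ug/mL to 100 ug/mL.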

Compound 3, half-maximal cytotoxic concentration: 64.1 ug/mL
Compound 3: middle estimate off by 1.4-fold (0.15 log units), on the low side, within the range that was stated.
By their numbers in this assay, from the lowest: compound 1; then compounds 3 and 2 (each within the scatter of the next).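

In this assay, trifluoromethyl in place of methoxy gives a 1.3-fold lower number from compound 2 to compound 3 (0.13 log units; within the scatter), so these two groups cannot be told apart on this aromatic carbon, while trifluoromethyl in place of fluoro gives a 2.0-fold higher number from compound 1 to compound 3 (0.31 log units; beyond the scatter), a modest separation. Among these three compounds, then, only the fluoro compound stands apart, and the earlier hint that a fluorine-bearing group gives the lower number does not hold, since compound 3 also carries fluorine yet sits clearly apart from compound 1. Nothing measured here explains these differences.

As far as these compounds go, whether an amine or a carboxylic acid on this carbon would match methoxy and trifluoromethyl or fall nearer fluoro remains open. Also open, from the compounds shown here alone, is whether the same ranking would hold with a longer chain in place of the cyclohexyl group on the shared core.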